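Swapping the triazole substituent back to cyclohexenyl

The source may hold more compounds than are shown below. What is called first, only, known or untested is meant among the compounds shown, and "the series" means these compounds.

Compound 1 `O=C1O/C(=C\Cn2cc(C3=CCCCC3)nn2)C(OCc2ccccc2)=C1OCc1ccccc1`: > 100000 nM
Compound 2 `O=C1O/C(=C\Cn2cc(-c3ccccc3)nn2)C(OCc2ccccc2)=C1OCc1ccccc1`: 44000 nM
Compound 3 `Cc1ccc(-c2cn(CCC3(O)NC(=O)C(OCc4ccccc4)=C3OCc3ccccc3)nn2)cc1`: 82200 nM

Of the compounds shown here, three have been tested in a functional assay on MDA-MB-231 cells (Homo sapiens) for antiproliferative activity, read by MTT assay, with a stated time of 24 h; on this read-out lower numbers stand for stronger inhibition and higher numbers for weaker inhibition. Compound 1 gives only a limit of the assay, > 100000 nM, and the same limit appears as the limit of > 100000 nM in this assay, at which 1 of the 3 values shown sits. Compound 2 gives 44000 nM. Compound 3 gives 82200 nM; this is the higher of the two real numbers, though its gap to compound 2 lies within the scatter, so no order between them can be claimed.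

Compound 4 `O=C1NC(O)(CCn2cc(C3=CCCCC3)nn2)C(OCc2ccccc2)=C1OCc1ccccc1` is not yet measured. It differs from compound 3 by cyclohex-1-en-1-yl in place of 4-methylphenyl on an aromatic carbon. For the measured compounds named here, the one measured step that bears on this change runs the opposite way: an at least 2.2-fold lower number from compound 1 to compound 2 (0.35 log units; beyond the scatter). Read in reverse, that step suggests that compound 4 should give a higher number than compound 3, with a fair chance of reaching the limit of this assay.

Compound 4 is therefore expected to give about 180000 nM, in a range from 80000 nM to 400000 nM, which amounts to an estimated step of a 2.2-fold higher number from compound 3 to compound 4 (0.34 log units; beyond the scatter).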

Compound 4, half-maximal inhibitory concentration: 13100 nM
Compound 4: middle estimate off by 14-fold (1.14 log units), on the high side, and the stated range ends above it.
By their numbers in this assay, from the lowest: compound 4; then compounds 2 and 3 (each within the scatter of the next). At a limit, above all of these: compound 1.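

In this assay, the step to the non-aromatic ring on the core of compound 3 is a 6.3-fold lower number from compound 3 to compound 4 (0.80 log units; beyond the scatter), which shows that cyclohex-1-en-1-yl at this position does not cost activity on every core. The earlier step, on the core of compound 1, ran the other way, an at least 2.2-fold lower number from compound 1 to compound 2 (0.35 log units; beyond the scatter), so the outcome of this kind of swap differs between the two cores, although that pair carries phenyl rather than 4-methylphenyl. The size of that earlier step stays a bound only, because compound 1 stands at a limit: the limit of > 100000 nM in this assay, at which 1 of the 4 values shown sits.

As far as these compounds go, it remains open how plain phenyl would compare with cyclohex-1-en-1-yl on the core of compound 3. From the compounds shown here alone, it is also open whether a saturated cyclohexyl ring, an amine or a longer alkyl chain on that aromatic carbon would keep the lower number.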